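This account rests on a few compounds, and the source may have more. Where it says the series, first, only, none or still open, it means among the compounds named here.

Of the compounds shown here, three sharing one core have been tested in a functional assay on PC-12 cells (Rattus norvegicus) for cytotoxicity, read by MTT assay, with stated times of 2 h and 24 h, tested at 5 uM; a higher number here means a stronger effect of the compound at the concentration tested, a lower number a weaker effect. Compound 1, `Cc1ccc(-n2nc(-c3ccc(C(F)(F)F)cc3O)nc2-c2ccccc2O)cc1`, gives 94.1% in this assay. Compound 2, `CCc1ccc(-n2nc(-c3ccc(C(F)(F)F)cc3O)nc2-c2ccccc2O)cc1`, gives 95.4%, and compound 3, `CC(C)c1ccc(-n2nc(-c3ccc(C(F)(F)F)cc3O)nc2-c2ccccc2O)cc1`, gives 100%. Compound 1 stands at one end of these three numbers, but every step leading away from it stays within the scatter: a number 1.3 percentage points higher from compound 1 to compound 2 (within the scatter) and a number 5.9 percentage points higher from compound 1 to compound 3 (within the scatter). Between the other two the picture is the same, since a number 4.6 percentage points higher from compound 2 to compound 3 (within the scatter).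

The next compound, compound 4, is `Oc1cc(C(F)(F)F)ccc1-c1nc(-c2ccccc2O)n(-c2ccc(F)cc2)n1`. It differs from compound 1 in one place: fluoro in place of methyl on an aromatic carbon. Among the measured compounds shown here, none of the measured steps involves a fluoro group; the three known steps all change a saturated or aromatic carbon substituent on the same ring and all lie within the scatter. They therefore offer no direct model for this change, only the observation that the three measured compounds give numbers close to one another in this assay. On that basis no step beyond the scatter is expected, so a number 0.1 percentage points lower from compound 1 to compound 4 (within the scatter) is the estimated outcome. Compound 4 is expected to give about 94% in this assay, with a likely range from 84% to 100%.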

Compound 4, a percentage reported as activity, at one concentration (the size of the read-out at that concentration, not a potency): 86.7%
Compound 4: middle estimate off by 7.3 percentage points, on the high side; low and high end bracket the measured number.
By their numbers in this assay, from the lowest: compounds 4, 1, 2 and 3 (each within the scatter of the next, the first and the last beyond it).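

Among the compounds shown here, compound 4 is the first to carry a fluoro rather than a carbon group at this place, on an aromatic carbon para to a large group, and in this assay it gives the first step beyond the scatter, a number 13.3 percentage points lower from compound 3 to compound 4 (beyond the scatter) for fluoro in place of isopropyl, a modest step. The methyl and ethyl compounds do not separate from it in the same way, with a number 7.4 percentage points lower from compound 1 to compound 4 (within the scatter) for fluoro in place of methyl and a number 8.7 percentage points lower from compound 2 to compound 4 (within the scatter) for fluoro in place of ethyl, so the difference between fluoro and isopropyl is the only one here that shows this place can register a change. Nothing at hand explains the number that compound 4 gives.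

The compounds shown leave open whether this step belongs to the fluoro group itself or to the loss of the isopropyl group; a chloro, a methoxy or a plain hydrogen at the same place would speak to that. They also leave open whether a longer chain, an amine or a carboxylic acid there would give a number in this assay that stands apart from those of the compounds shown.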